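Swapping tert-butyl for chloro in a growth-inhibiting amide series

The source may hold more compounds than are shown below. What is called first, only, known or untested is meant among the compounds shown, and "the series" means these compounds.

Compound 1 `Nc1ccccc1NC(=O)c1ccc(CSc2cccc(F)c2)cc1` gives 81.4% in growth inhibition
Compound 2 `CC(C)(C)c1ccc(SCc2ccc(C(=O)Nc3ccccc3N)cc2)cc1` gives 60.5% in growth inhibition
Compound 3 `COc1ccc(SCc2ccc(C(=O)Nc3ccccc3N)cc2)cc1OC` gives 91.5% in growth inhibition

These three compounds share one core and differ in the groups on one end of the molecule. They were tested in a functional assay on HCT-116 cells (Homo sapiens) for inhibition, read by CCK-8 assay, with a stated time of 72 h, tested at 8 uM (on this read-out lower numbers stand for less inhibition of growth and higher numbers for more inhibition of growth at the one concentration tested), and the spread between them is wide. Compound 2 gives 60.5% and stands lowest of the three, with both other compounds lying above it by more than the usual scatter.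

The next compound to be measured is compound 4 `Nc1ccccc1NC(=O)c1ccc(CSc2ccc(Cl)cc2)cc1` with chloro in place of tert-butyl on an aromatic carbon. The change is counted here: chloro in place of tert-butyl on an aromatic carbon and it sits para to a large group.

Among the compounds with values here, no two measured compounds differ in only one place, so no direct step can guide the forecast. The closest clue is compound 1, which also bears a halogen and gives 81.4% as its value. The estimated step of a number 17.5 percentage points higher from compound 2 to compound 4 (beyond the scatter) is therefore expected to point upward and to lie beyond the usual scatter, though with real uncertainty. In this assay the estimated value for compound 4 is 78% and the expected range runs from 60% to 93% as a working forecast.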

Compound 4, percent growth inhibition at one concentration: 76.6%
Compound 4: the middle estimate sits 1.4 percentage points above what was measured, and the stated range covers the measured number.
By their numbers in this assay, from the lowest: compound 2; then compounds 4 and 1 (each within the scatter of the next); then compound 3.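

In this assay, within the data shown here, chloro in place of tert-butyl on an aromatic carbon, para to a large group, gives a number 16.1 percentage points higher from compound 2 to compound 4 (beyond the scatter) and provides the first direct one-place comparison. It shows that the reading responds to the group at this position, and that a tert-butyl group of four heavy atoms and a chloro group of one are not interchangeable there. The second comparison changes the aromatic group on the sulfur, with 4-chlorophenyl in place of 3-fluorophenyl, and gives a number 4.8 percentage points lower from compound 1 to compound 4 (within the scatter) with no difference that can be separated from ordinary repeat variation.

Each change rests on a single pair, so the compounds shown do not reveal how the reading would respond to an amine, a carboxylic acid or a longer chain at the same position on the ring. They also leave open why tert-butyl and chloro differ, since no supporting measurement bears on this result.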